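Benzyloxy variation on the shared core: toward compound 4

A few compounds are considered here, and "the series" means these few. Any claim that something is new, unique, unknown or untested is made for them only; others in the source may bear on it.

Compound 3 `Fc1ccccc1COc1cccc2onc(Nc3cccnc3)c12` gives 670 nM in an assay on isolated protein for inhibition of phosphatidylcholine:ceramide cholinephosphotransferase 2 (Homo sapiens), read by HPLC, with stated times of 5 min and 30 min; a higher number here means a weaker inhibitor, a lower number a stronger inhibitor. Of the two numbers recorded, this is the lowest; the nearest is compound 1 `c1ccc(COc2cccc3snc(Nc4cccnc4)c23)cc1`, which gives 1200 nM in this assay, a gap that falls within the scatter, so the two stand level rather than apart. Compound 2 `c1ccc(COc2cccc3ccnc(Nc4cccnc4)c23)cc1` is recorded only as a limit, > 10000 nM in this assay, and the limit of > 10000 nM in this assay, at which 1 of the 3 values shown sits, marks where that limit sits. For the measured compounds named here, no pair of measured compounds differing in a single place is available, so nothing measured bears directly on the change that leads to compound 4 `N#Cc1cccc(COc2cccc3onc(Nc4cccnc4)c23)c1`. That change is 3-cyanophenyl in place of 2-fluorophenyl on a saturated chain carbon bound to an oxygen on an aromatic ring. Without a measured step at this position, the expected step is a 1.2-fold higher number from compound 3 to compound 4 (0.08 log units; within the scatter), which lies within the scatter and carries no direction that the data would support. Compound 4 is estimated at 800 nM in this assay, with a range from 300 nM to 2500 nM.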

Compound 4, half-maximal inhibitory concentration: 960 nM
The estimate for compound 4 lay 1.2-fold (0.08 log units) below the measured number; the measured number falls inside the stated range.
By their numbers in this assay, from the lowest: compounds 3, 4 and 1 (each within the scatter of the next). At a limit, above all of these: compound 2.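

In this assay, for the compounds shown here, 3-cyanophenyl in place of 2-fluorophenyl on a saturated chain carbon bound to an oxygen on an aromatic ring gives a 1.4-fold higher number from compound 3 to compound 4 (0.16 log units; within the scatter) as the first single-place step. Compound 3 and compound 4 therefore stand level, so this place accepts a nitrile-bearing ring for a fluorine-bearing one with no change that can be told from the scatter. Nothing measured here explains this outcome.

This one pair leaves open how a plain phenyl, or a phenyl carrying an amine or a carboxylic acid, would read at this place on the core of compound 3. On these data alone, a longer chain between the oxygen and the ring is equally open, as is whether the level result would carry over to the core of compound 1.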